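Replacing the nitro of compound 1 with a carbamoyl arm

This account rests on a few compounds, and the source may have more. Where it says the series, first, only, none or still open, it means among the compounds named here.

In a functional assay on HCC827 cells (Homo sapiens) for cytotoxicity, read by MTT assay, with a stated time of 72 h (on this read-out higher numbers stand for weaker inhibition and lower numbers for stronger inhibition), compound 1 (`CN1CCN(c2ccc(Nc3ncc4nc(Nc5cccc([N+](=O)[O-])c5)n(C5CCCC5)c4n3)cc2)CC1`) gives < 0.01 nM, which is a limit and not a number. Compound 2 (`CN1CCN(c2ccc(Nc3ncc4nc(Nc5ccc(Br)cc5)n(C5CCCC5)c4n3)cc2)CC1`) gives 2.2 nM. Compound 3 (`CN1CCN(c2ccc(Nc3ncc4nc(Nc5cccc(C(=O)Nc6ccc(Cl)cc6)c5)n(C5CCCC5)c4n3)cc2)CC1`) carries (4-chlorophenyl)carbamoyl in place of nitro on an aromatic carbon. Within the data shown here, the one measured step that bears on this also loses the nitro and is large: an at least 220-fold higher number from compound 1 to compound 2 (2.34 log units; beyond the scatter). On that single step, a higher number is expected in this assay. The expected step is an at least 100-fold higher number from compound 1 to compound 3 (2.00 log units; beyond the scatter). For compound 3 the estimated value is 1 nM, with an expected range of 0.05 nM to 20 nM.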

Compound 3, half-maximal inhibitory concentration: 2900 nM
The estimate for compound 3 lay 2900-fold (3.46 log units) below the measured number, outside the stated range (above it).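

In this assay, (4-chlorophenyl)carbamoyl in place of nitro on this aromatic carbon gives an at least 290000-fold higher number from compound 1 to compound 3 (5.46 log units; beyond the scatter), so this position does not accept every replacement for nitro. The change sits in this one place, with the rest of compound 1 untouched. Compound 1 is held only as a limit, so the size of this step is a bound: the limit of < 0.01 nM in this assay, at which 1 of the 3 values shown sits.

Going by these compounds, whether the loss follows the carbamoyl link or the added 4-chlorophenyl ring stays open. An amine or an unsubstituted carbamoyl at this place would separate the two.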